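Swapping a Pyrrole for Methoxy: Cytotoxicity Outlook

This account rests on a few compounds, and the source may have more. Where it says the series, first, only, none or still open, it means among the compounds named here.

Compound 1 `COC(=O)c1ccc(NCc2cncn2Cc2ccccc2N)cc1-c1ccccc1` gives 25000 nM in this study.
Compound 2 `c1ccc(-c2ccc(Cn3cncc3CNc3ccc(-c4ccc[nH]4)c(-c4ccccc4)c3)cc2)cc1` gives > 10000 nM.
Compound 3 `Clc1ccc(Cn2cncc2CNc2ccc(-c3nc4ccccc4s3)c(-c3ccccc3)c2)cc1` gives > 1000 nM.

All three were tested in a toxicity assay on NIH3T3 cells (Mus musculus) for cytotoxicity, read by resazurin assay; a higher number here means that more compound is needed for the effect, a lower number that less compound is needed. Among the compounds with values here, compound 1 is the only one with a measured number. For compound 2 the result is a limit of the assay, not a number (the limit of > 10000 nM in this assay, at which 1 of the 3 values shown sits). For compound 3 the result is also a limit (the limit of > 1000 nM in this assay, at which 1 of the 3 values shown sits). Compound 4 `COc1ccc(NCc2cncn2Cc2ccc(-c3ccccc3)cc2)cc1-c1ccccc1` has not been measured. It differs from compound 2 in one place: methoxy in place of 1H-pyrrol-2-yl on an aromatic carbon. Within the data shown here, no step between two measured compounds is available, so the size of this change in this assay cannot be read from the data. I expect no shift beyond the usual scatter, with a step that the limit leaves unreadable from compound 2 to compound 4. My estimate for compound 4 is 20000 nM, in a range from 6000 nM to 60000 nM.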

Compound 4, half-maximal effective concentration: > 1000 nM
Compound 4 was reported as a limit; the forecaster's own chance of this, stated with the estimate: 50%; the middle value lies beyond the limit too.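

Compound 2 and compound 4 both stand as limits, not numbers, so the step between them cannot be read. The compounds shown leave open whether methoxy in place of 1H-pyrrol-2-yl changes the result in this assay at all.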